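This account rests on a few compounds, and the source may have more. Where it says the series, first, only, none or still open, it means among the compounds named here.

Working notes on the series. Among the measured compounds shown here, in a functional assay on the whole organism (strain CD-1) with Mus musculus as the target, in the maximal electroshock model, with a stated time of 2 h (on this read-out lower numbers stand for an effect already at smaller amounts and higher numbers for an effect only at larger amounts of compound), compound 1 `CC1(c2ccccc2)CC(=O)N(CC(=O)N2CCN(c3cccc(Cl)c3)CC2)C1=O` gives 300 mg/kg, the only number obtained so far for this series, and a weak one on the scale of this read-out. For the measured compounds named here, compound 2 `CC1(c2ccccc2)CC(=O)N(CC(=O)N2CCN(c3ncccn3)CC2)C1=O` is the other entry: in this assay compound 2 is reported as "not active" (no number reported), without any number, so it offers no step to compare against and says only that the series can lose its effect altogether.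

Compound 3 `CC1(c2ccccc2)CC(=O)N(CC(=O)N2CCN(c3cccc(C(F)(F)F)c3)CC2)C1=O` has not been tested. It differs from compound 1 in one place: trifluoromethyl in place of chloro on an aromatic carbon. Going by the values given here, no pair of measured compounds differing in a single place is available, so the size of this step cannot be read from the data; the expectation rests on compound 1 alone. A change within the usual scatter, or a small move in either direction, is expected, with the step from compound 1 to compound 3 estimated at no change at the digits printed from compound 1 to compound 3 (within the scatter). For compound 3 the expected value in this assay is 300 mg/kg, within a range of 100 mg/kg to 600 mg/kg, with a real chance that, as for compound 2, no number is obtained at all.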

Compound 3, minimum effective dose: 300 mg/kg
For compound 3 middle estimate and measured number coincide at the digits printed, within the range that was stated.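

Trifluoromethyl in place of chloro on this aromatic carbon, with 4 heavy atoms entering where 1 leaves, is the first step in the series that can be read in this assay, and it comes out at no change at the digits printed from compound 1 to compound 3 (within the scatter). Among the compounds shown here, the effect at this place on the ring is therefore not tied to chloro itself: the 3-chlorophenyl and 3-(trifluoromethyl)phenyl compounds read alike, something that the single number for compound 1 and the entry without a number for compound 2 could not show. No measurement at hand bears on why these two groups read alike.

Going by these compounds, it remains open whether this place on the ring also keeps the effect with an amine, a carboxylic acid or a methoxy group, or whether one of these would shift the minimum effective dose beyond the scatter or remove the effect altogether. For the compounds shown here, also open is how the read-out responds to changes elsewhere in the molecule, for example a longer chain in place of the methyl group on the shared core, since the only step available concerns this one aromatic carbon.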